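A methoxy in place of bromo on an aromatic carbon

The compounds below may be only part of what the source reports. "The series", "measured", "known", "first", "only" and "open" are said of these compounds alone.

Compound 1 `COc1ccc(/C=C/C(=O)C(=Cc2ccc(O)c(F)c2)C(=O)/C=C/c2ccc(OC)cc2OC)c(OC)c1` gives 1760 nM
Compound 2 `COc1ccc(/C=C/C(=O)C(=Cc2cc(Br)c(O)c(OC)c2)C(=O)/C=C/c2ccc(OC)cc2OC)c(OC)c1` gives 1190 nM

Going by the values given here, in a functional assay on HepG2 cells (Homo sapiens) for antiproliferative activity, read by sulforhodamine B assay, with a stated time of 48 h (a higher number here means a weaker inhibitor, a lower number a stronger inhibitor), compound 2 gives 1190 nM and lies within the scatter of compound 1 at 1760 nM on the only two numbers available, so neither is set apart. Compound 3 `COc1ccc(/C=C/C(=O)C(=Cc2cc(OC)c(O)c(OC)c2)C(=O)/C=C/c2ccc(OC)cc2OC)c(OC)c1` differs from compound 2 by methoxy in place of bromo on an aromatic carbon in one place: methoxy in place of bromo on an aromatic carbon, ortho to a hydroxy group, which gives 4-hydroxy-3,5-dimethoxyphenyl. Among the compounds with values here, no measured step makes this exact exchange. Within the data shown here, the only step available is a 1.5-fold lower number from compound 1 to compound 2 (0.17 log units; within the scatter) and it also exchanged that aromatic group. Among the measured compounds shown here, with only that small step to go on, no change beyond the scatter is expected in this assay in either direction. The expected step is a 1.1-fold higher number from compound 2 to compound 3 (0.04 log units; within the scatter) on this estimate. Compound 3 is estimated at 1300 nM with an expected range of 600 nM to 2800 nM in this measurement.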

Compound 3, half-maximal inhibitory concentration: 320 nM
Compound 3: middle estimate off by 4.1-fold (0.61 log units), on the high side; measured number below the stated range.
By their numbers in this assay, from the lowest: compound 3; then compounds 2 and 1 (each within the scatter of the next).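

In this assay, the exchange of bromo for methoxy on an aromatic carbon ortho to a hydroxy group gives a 3.7-fold lower number from compound 2 to compound 3 (0.57 log units; beyond the scatter) and so shows that this position responds beyond the scatter, which the earlier step, a 1.5-fold lower number from compound 1 to compound 2 (0.17 log units; within the scatter), had not shown. The 4-hydroxy-3,5-dimethoxyphenyl group also separates compound 3 from the 3-fluoro-4-hydroxyphenyl compound, with a 5.5-fold lower number from compound 1 to compound 3 (0.74 log units; beyond the scatter), while compound 1 and compound 2 remain within the scatter of each other. No measurement given here accounts for the difference between bromo and methoxy at this position.

The compounds shown leave open whether the step comes from gaining methoxy or from losing bromo, which a plain hydrogen in that place could help to separate. They also leave open how an ethoxy group or an amine would read at this position.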